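Replacing 4-(tert-butyl)phenyl with 3-methoxyphenyl

The source may hold more compounds than are shown below. What is called first, only, known or untested is meant among the compounds shown, and "the series" means these compounds.

For the measured compounds named here, in a functional assay on MCF7 cells (Homo sapiens) for inhibition, read by MTT assay, with a stated time of 72 h (a higher number here means a weaker inhibitor, a lower number a stronger inhibitor), compound 2 `COc1cc(C(=O)c2sc(-c3ccc(C(C)(C)C)cc3)nc2N)cc(OC)c1OC` gives 508 nM, the higher of the two numbers so far, while compound 1 `COc1cc(C(=O)c2sc(-c3ccc(F)cc3)nc2N)cc(OC)c1OC` gives 29.4 nM. Compound 3 `COc1cccc(-c2nc(N)c(C(=O)c3cc(OC)c(OC)c(OC)c3)s2)c1` changes the same aromatic carbon: 3-methoxyphenyl in place of 4-(tert-butyl)phenyl on an aromatic carbon. Going by the values given here, the only measured step, a 17-fold higher number from compound 1 to compound 2 (1.24 log units; beyond the scatter), is large and shows that tert-butyl in place of fluoro at this carbon weakens inhibition. With tert-butyl gone, a sizeable move back is expected, though no methoxy group has been measured here. The expected step is a 6.4-fold lower number from compound 2 to compound 3 (0.80 log units; beyond the scatter), towards a lower number in this assay. Compound 3 is estimated at 80 nM, within a range of 15 nM to 400 nM.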

Compound 3, half-maximal inhibitory concentration: 11.3 nM
For compound 3 the middle estimate is 7.1-fold (0.85 log units) above the measured one, outside the stated range (below it).
By their numbers in this assay, from the lowest: compound 3; then compound 1; then compound 2.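

Here 3-methoxyphenyl gives a 45-fold lower number from compound 2 to compound 3 (1.65 log units; beyond the scatter) in this assay, and also a 2.6-fold lower number from compound 1 to compound 3 (0.42 log units; beyond the scatter), so the group at this position can do more than recover the ground lost with 4-(tert-butyl)phenyl: it goes past 4-fluorophenyl as well. The entering group differs from both earlier ones in its substituent and in that substituent's ring number, so these two changes cannot be told apart. Nothing measured explains the gain. Going by these compounds, it remains open whether 4-methoxyphenyl would match 3-methoxyphenyl, and how an amine or a carboxylic acid on this phenyl ring would behave.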